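Replacing an Ethyl Arm with a Pyridin-2-yl Ring

The source may hold more compounds than are shown below. What is called first, only, known or untested is meant among the compounds shown, and "the series" means these compounds.

Compound 1 `CCC(c1ccccc1)c1nc(-c2ccc(Cl)cc2)c(CC(=O)O)s1` carries an ethyl group on a saturated chain carbon that also holds a phenyl ring and the shared core. As far as these compounds go, in an in vitro functional assay on HEK285-7 cells for antagonist activity at prostaglandin D2 receptor 2 (Homo sapiens), read by BRET and beta-arrestin recruitment (on this read-out lower numbers stand for stronger inhibition and higher numbers for weaker inhibition), compound 1 reaches only the limit of > 100000 nM, so its true value is unknown and can be said only to lie beyond what the test reports. Compound 2 `O=C(O)Cc1sc(COc2ccc(Cl)cc2)nc1-c1ccc(Cl)cc1`, which replaces that whole arm with a chlorophenoxymethyl group, gives 370 nM in this assay; the two results show that changes at this position can move the read-out a long way, as the line the limit of > 100000 nM in this assay, at which 1 of the 2 values shown sits, makes clear for compound 1.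

Compound 3 `O=C(O)Cc1sc(C(c2ccccc2)c2ccccn2)nc1-c1ccc(Cl)cc1` keeps everything else of compound 1 and differs in one place: pyridin-2-yl in place of ethyl on a saturated chain carbon bound to two aromatic carbons. Among the measured compounds shown here, no measured pair makes exactly this move, so the size of the step rests on expectation alone. Because compound 1 sits at a limit of > 100000 nM, only the direction toward stronger inhibition can be estimated, and the step from compound 1 to compound 3 is expected to be an at least 50-fold lower number from compound 1 to compound 3 (1.69 log units; beyond the scatter). Compound 3 is therefore expected to give about 2000 nM in this assay, somewhere between 200 nM and 30000 nM.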

Compound 3, half-maximal inhibitory concentration: 1900 nM
The estimate for compound 3 lay 1.1-fold (0.02 log units) above the measured number, and the stated range covers the measured number.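

In this assay, pyridin-2-yl in place of ethyl on a saturated chain carbon bound to two aromatic carbons gives an at least 52-fold lower number from compound 1 to compound 3 (1.72 log units; beyond the scatter). The earlier compounds shown here differed by a whole arm, whereas here the phenyl ring, the chain carbon and the shared core all stay, which ties this large step to one group on that carbon and shows that this single exchange is enough to bring the read-out within the range of the test. Compound 1 stands at a limit, and the step therefore gives only a smallest possible size and not a true one: the limit of > 100000 nM in this assay, at which 1 of the 3 values shown sits.

As far as these compounds go, what remains open is whether the step depends on the ring nitrogen of pyridin-2-yl, on the aromatic ring, or simply on a larger group than ethyl at this place. A pyridin-3-yl or cyclohexyl group on the same carbon would help to separate these possibilities, and with a single step in hand, no general rule for this position can yet be drawn.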